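Taking a methyl off a weak growth inhibitor

A few compounds are considered here, and "the series" means these few. Any claim that something is new, unique, unknown or untested is made for them only; others in the source may bear on it.

Of the compounds shown here, three that share one core have been tested in a functional assay on MV4-11 cells (Homo sapiens) for inhibition, read by resazurin assay, with a stated time of 72 h (a lower number here means a stronger inhibitor of growth, a higher number a weaker inhibitor of growth), so far. Compound 1 (`O=[N+]([O-])c1cccc(Nc2ncc3c(n2)CCCC3)c1`) gives 3500 nM in this test. Compound 3 (`Cc1ccc(Nc2ncc3c(n2)CCCC3)cc1`) gives 6000 nM and so stands within the usual scatter of compound 1, with no real gap between them. Compound 2 (`Cc1ccccc1Nc1ncc2c(n1)CCCC2`) reads > 10000 nM, which is a limit and not a number.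

Compound 4 (`c1ccc(Nc2ncc3c(n2)CCCC3)cc1`) differs from compound 3 in one place (hydrogen in place of methyl on an aromatic carbon), with hydrogen in place of methyl on an aromatic carbon. Among the measured compounds shown here, no measured pair of compounds shows this change on its own, so the expectation rests on little. No step beyond the scatter is expected in this assay, which would leave compound 4 close to compound 3 at 6000 nM. The estimated change is a 1.1-fold lower number from compound 3 to compound 4 (0.04 log units; within the scatter). For compound 4 the expected value is 5500 nM, with an estimated range from 2500 nM to 10000 nM.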

Compound 4, concentration for 50% growth inhibition: 9830 nM
Estimate against measurement, compound 4: 1.8-fold (0.25 log units) below; the measured number falls inside the stated range.
By their numbers in this assay, from the lowest: compounds 1, 3 and 4 (each within the scatter of the next, the first and the last beyond it). At a limit, above all of these: compound 2.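

In this assay, hydrogen in place of the methyl para to a large group gives a 1.6-fold higher number from compound 3 to compound 4 (0.21 log units; within the scatter); this methyl makes no clear difference to growth inhibition here. The unsubstituted compound also gives the first clear gap in the series, as the nitro group of compound 1 stands apart from hydrogen, with a 2.8-fold higher number from compound 1 to compound 4 (0.45 log units; beyond the scatter) marking a modest step. Hydrogen in place of methyl on an aromatic carbon also gives an at least 1.0-fold lower number from compound 2 to compound 4 (0.00 log units; that floor lies within the scatter), but this step shows only a floor. Compound 2 reads as a limit and not a number: the limit of > 10000 nM in this assay, at which 1 of the 4 values shown sits.

As far as these compounds go, whether an amine or a carboxylic acid on the same aromatic ring would give a larger step than nitro stays open. So does whether the nitro step would hold at the place that the methyl of compound 3 occupies.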